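This account rests on a few compounds, and the source may have more. Where it says the series, first, only, none or still open, it means among the compounds named here.

In an ADME assay on liver for metabolic stability, with Liver microsome (Rattus norvegicus) as the target, read by LC-MS, using microsomes, with a stated time of 5 h (a lower number here means slower removal, a higher number faster removal of the compound), compound 1 `C[C@]1(O)C[C@](c2ccc(OC(F)(F)F)cc2)([C@H](O)c2ccccn2)C1` gives 100 mL/min/kg. Compound 2 `C[C@]1(O)C[C@](c2cccc(C(F)(F)F)c2)([C@H](O)c2ccccn2)C1` gives 66.7 mL/min/kg, and these two numbers lie within the usual scatter of each other. Compound 3 `C[C@]1(O)C[C@@](c2ccc(OC(F)(F)F)cc2)([C@H](O)c2ccccn2)C1` is built from the same pieces as compound 1: the two compounds have the same atoms and bonds and differ only in configuration as drawn: 2 of 3 stereo elements differ; a stereocentre at a saturated ring carbon is drawn S in compound 1 and R in compound 3; a stereocentre at a saturated ring carbon is drawn r in compound 1 and s in compound 3. Among the measured compounds shown here, no measured pair here shows what such a change in configuration does, so no change beyond the scatter is expected, and no direction can be argued. The estimated step of a 1.2-fold lower number from compound 1 to compound 3 (0.07 log units; within the scatter) is therefore a small one. Compound 3 is expected at 85 mL/min/kg, with a range of 40 mL/min/kg to 160 mL/min/kg.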

Compound 3, clearance: 133 mL/min/kg
Compound 3: middle estimate off by 1.6-fold (0.19 log units), on the low side; low and high end bracket the measured number.
By their numbers in this assay, from the lowest: compounds 2, 1 and 3 (each within the scatter of the next).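

The pair gives a direct reading of a change in configuration, which compounds 1 and 2 could not give: in this assay, redrawing two of the three stereo elements gives a 1.3-fold higher number from compound 1 to compound 3 (0.12 log units; within the scatter). Nothing else separates the pair: the fact that compounds 1 and 3 differ only in the configuration as drawn. For this pair, then, the configuration at these two ring carbons leaves the clearance within the usual scatter.

On these data alone, whether the same holds with the trifluoromethyl group of compound 2 in place of the trifluoromethoxy group remains open. So does what an amine or a carboxylic acid on the shared core would do to this number.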